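This account rests on a few compounds, and the source may have more. Where it says the series, first, only, none or still open, it means among the compounds named here.

Three compounds of one shared core were tested in an assay on isolated protein for inhibition of Rho-associated protein kinase 1 (Homo sapiens), read by scintillation counting, radiometric assay and 33P incorporation, with a stated time of 40 min, in the presence of a further agent that is not named here; on this read-out lower numbers stand for stronger inhibition and higher numbers for weaker inhibition. Compound 2, `COc1cc(OCC(=O)Nc2cccc(NC(=O)c3ccc(N(C)C)cc3)c2)ccc1C=O`, gives 3740 nM in this assay, the highest of the two numbers recorded; its nearest neighbour is compound 3, at a 26-fold lower number from compound 2 to compound 3 (1.41 log units; beyond the scatter). Compound 3, `CN(C)c1ccc(C(=O)Nc2cccc(NC(=O)COc3ccc4c(c3)OCCC4=O)c2)cc1`, gives 144 nM. Compound 1, `COc1cccc(OCC(=O)Nc2cccc(NC(=O)c3ccc(N(C)C)cc3)c2)c1`, returns only a limit in this assay, > 10000 nM, which is the limit of > 10000 nM in this assay, at which 1 of the 3 values shown sits. From compound 1 the steps run an at least 2.6-fold lower number from compound 1 to compound 2 (0.42 log units; beyond the scatter) and an at least 69-fold lower number from compound 1 to compound 3 (1.84 log units; beyond the scatter).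

The next compound, compound 4, is `CN(C)c1ccc(C(=O)Nc2cccc(NC(=O)COc3ccc4occc(=O)c4c3)c2)cc1`. Relative to compound 2 the change is a group of 11 heavy atoms (9 carbon, 2 oxygen; one six-membered aromatic ring of carbon only, one six-membered aromatic ring with 1 hetero atom) in place of a group of 10 heavy atoms (8 carbon, 2 oxygen; one six-membered aromatic ring of carbon only), on an oxygen on a saturated carbon. Within the data shown here, the step that bears most directly on this is the one from compound 2 to compound 3, where a bicyclic group of similar size entered at the same place and the number fell greatly, a 26-fold lower number from compound 2 to compound 3 (1.41 log units; beyond the scatter). The step from compound 1 to compound 3 points the same way. A large fall is therefore expected for compound 4 as well, with a step estimated at a 19-fold lower number from compound 2 to compound 4 (1.27 log units; beyond the scatter). For compound 4 the expected value in this assay is 200 nM, with a likely range from 50 nM to 800 nM.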

Compound 4, half-maximal inhibitory concentration: > 10000 nM
Compound 4: no number, only a limit; the forecaster's own chance of this, stated with the estimate: 2%; at least 50-fold (1.69 log units) between middle value and limit.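

Two groups with the same count of heavy atoms, on the same oxygen, can give very different results: making the six-membered ring with 1 hetero atom aromatic produces an at least 69-fold higher number from compound 3 to compound 4 (1.84 log units; beyond the scatter). A second ring at this place therefore does not bring stronger inhibition by itself, and here the two-ring group falls short even of the single-ring group it replaces, with an at least 2.6-fold higher number from compound 2 to compound 4 (0.42 log units; beyond the scatter). Compound 1 and compound 4 each return only a limit, and the step between them cannot be read: the limit of > 10000 nM in this assay, at which 2 of the 4 values shown sit.

On these data alone, how far compound 4 really lies past its limit stays unknown, and so does whether the loss belongs to the aromatic ring as such or to some other difference in how the two groups are built. The compounds shown also do not tell how the more active ring of compound 3 would fare with an amine nitrogen in place of its ring oxygen, or whether a longer chain on the oxygen would change the gap between the non-aromatic and the aromatic ring.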